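Moving away from the 2-chlorophenyl group of compound 2

This account rests on a few compounds, and the source may have more. Where it says the series, first, only, none or still open, it means among the compounds named here.

Three compounds share one core and differ only in the ring group on a saturated chain carbon bound to a sulfur. All three were tested in a functional assay on HepG2 cells (Homo sapiens) for antiproliferative activity, read by MTT assay, with a stated time of 24 h; a lower number here means a stronger inhibitor, a higher number a weaker inhibitor. Compound 1 `O=[N+]([O-])c1ccc(CSc2nnc(-c3ccc4c(c3)OCCO4)n2-c2ccccc2)cc1`, carrying 4-nitrophenyl, gives 13800 nM. Compound 3 `COc1cccc(CSc2nnc(-c3ccc4c(c3)OCCO4)n2-c2ccccc2)c1`, carrying 3-methoxyphenyl, gives 35100 nM. Compound 2 `Clc1ccccc1CSc1nnc(-c2ccc3c(c2)OCCO3)n1-c1ccccc1`, carrying 2-chlorophenyl, gives 970 nM, the lowest number of the three and so the strongest inhibitor here.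

Compound 4 `Cc1ccc(CSc2nnc(-c3ccc4c(c3)OCCO4)n2-c2ccccc2)cc1` has not yet been measured. It differs from compound 2 by one change: 4-methylphenyl in place of 2-chlorophenyl on a saturated chain carbon bound to a sulfur. In words, 4-methylphenyl stands in place of 2-chlorophenyl on that same chain carbon.

Among the measured compounds shown here, two measured steps bear on this change, since each also swaps the 2-chlorophenyl group for another ring group. The data show a 14-fold lower number from compound 1 to compound 2 (1.15 log units; beyond the scatter), which read backwards is a large rise, and a 36-fold higher number from compound 2 to compound 3 (1.56 log units; beyond the scatter). For the measured compounds named here, both swaps therefore cost a great deal, although no methyl-bearing compound has been measured. A large step towards a higher number is expected in this assay. The estimated step is a 12-fold higher number from compound 2 to compound 4 (1.09 log units; beyond the scatter). The estimate for compound 4 is 12000 nM, with an expected range of 3000 nM to 40000 nM.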

Compound 4, half-maximal inhibitory concentration: 56800 nM
For compound 4 the middle estimate is 4.7-fold (0.68 log units) below the measured one; the whole stated range lies below it.
By their numbers in this assay, from the lowest: compound 2; then compound 1; then compounds 3 and 4 (each within the scatter of the next).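

In this assay, the 2-chlorophenyl group now stands apart from a third ring group, and this one carries only a methyl: the change gives a 59-fold higher number from compound 2 to compound 4 (1.77 log units; beyond the scatter) and so joins the two earlier swaps in losing most of the activity of compound 2. Among these four compounds, every ring group other than 2-chlorophenyl gives a far higher number, and none goes against this pattern. The other ring groups also begin to sort among themselves: a 1.6-fold higher number from compound 3 to compound 4 (0.21 log units; within the scatter) means that 4-methylphenyl and 3-methoxyphenyl cannot be told apart here, whereas methyl in place of nitro gives a 4.1-fold higher number from compound 1 to compound 4 (0.61 log units; beyond the scatter) and leaves 4-nitrophenyl the better of the two.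

Among the compounds shown here, compound 2 is the only compound here that carries a chlorine, so these data cannot separate the effect of the chlorine from that of its place on the ring, and an unsubstituted phenyl group or a fluorine in place of the chlorine would help to settle this. No measurement shown here accounts for the low number of compound 2.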